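Swapping the halophenyl arm on a thiazolethione core

A few compounds are considered here, and "the series" means these few. Any claim that something is new, unique, unknown or untested is made for them only; others in the source may bear on it.

Measured compounds:
compound 1, `COc1cc(N2C(=S)SCC2(O)c2ccc(Br)cc2)cc(OC)c1OC`: 15.1 ug/mL
compound 2, `COc1cc(-n2c(-c3ccc(Br)cc3)csc2=S)cc(OC)c1OC`: 58 ug/mL

In a functional assay on MDA-MB-231 cells (Homo sapiens) for cytotoxicity, read by MTT assay, with a stated time of 48 h (on this read-out lower numbers stand for stronger inhibition and higher numbers for weaker inhibition), compound 2 gives the higher of the two numbers; compound 1 gives the lower one, and the gap between them is beyond the scatter. Compound 3, `COc1cc(-n2c(-c3ccc(Cl)cc3Cl)csc2=S)cc(OC)c1OC`, has not been measured. It differs from compound 2 in one place: 2,4-dichlorophenyl in place of 4-bromophenyl on an aromatic carbon. Going by the values given here, no measured pair shows this change, so the step is expected to be small, in no clear direction, and likely within the scatter. For compound 3 the expected result in this assay is 50 ug/mL, with a range from 20 ug/mL to 120 ug/mL, a step of a 1.2-fold lower number from compound 2 to compound 3 (0.06 log units; within the scatter).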

Compound 3, half-maximal inhibitory concentration: 49 ug/mL
For compound 3 the middle estimate is 1.0-fold (0.01 log units) above the measured one; low and high end bracket the measured number.
By their numbers in this assay, from the lowest: compound 1; then compounds 3 and 2 (each within the scatter of the next).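

In this assay, putting 2,4-dichlorophenyl in place of 4-bromophenyl on this aromatic carbon gives a 1.2-fold lower number from compound 2 to compound 3 (0.07 log units; within the scatter), so the two compounds cannot be told apart. At this position, then, one halogen-bearing phenyl arm can stand in for the other without a readable effect on the number. Nothing available here explains this result. Both arms are halogenated phenyl rings, so this single pair says nothing about very different groups. An amine or a carboxylic acid on the phenyl ring, or a longer chain in place of the ring, remains an open question.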